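A few compounds are considered here, and "the series" means these few. Any claim that something is new, unique, unknown or untested is made for them only; others in the source may bear on it.

Measured compounds in an assay on HEK293 cells for displacement of a labelled ligand from sodium-dependent dopamine transporter (Homo sapiens), read by scintillation proximity assay and radioligand binding; a higher number here means a weaker inhibitor, a lower number a stronger inhibitor:
compound 1, `CC(C)N(C(=O)c1ccccc1C(F)(F)F)[C@H]1CCNC1`; compound 1 gives > 10000 nM, a limit of the assay rather than a number.
compound 2, `O=C(c1ccccc1C(F)(F)F)N(CC1CCCC1)[C@H]1CCNC1`; compound 2 gives 2750 nM.

Within the data shown here, compound 2 carries the only numerical value shown in this assay; the other entry is a limit. Among the measured compounds shown here, the single measured step, an at least 3.6-fold lower number from compound 1 to compound 2 (0.56 log units; beyond the scatter), rests on the limit of > 10000 nM in this assay, at which 1 of the 2 values shown sits, for its starting point, so its size is known only as a floor.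

Compound 3, `CC(C)c1ccccc1C(=O)N(CC1CCCC1)[C@H]1CCNC1`, is not yet measured. It differs from compound 2 by isopropyl in place of trifluoromethyl on an aromatic carbon. The measured step concerns the substituent on the amide-type nitrogen, not the substituent on the aromatic ring, which carries the same trifluoromethyl in compound 1 and compound 2. For the measured compounds named here, no measured step bears on this change. In the absence of a bearing step, no change beyond the scatter is expected in this assay, in either direction, and the spread of the estimate is kept wide. Compound 3 is accordingly estimated at 3000 nM in this assay, within 700 nM to 13000 nM. The expected step is a 1.1-fold higher number from compound 2 to compound 3 (0.04 log units; within the scatter).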

Compound 3, inhibition constant: 3470 nM
For compound 3 the middle estimate is 1.2-fold (0.06 log units) below the measured one; measured number inside the range.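

Among these compounds, the aromatic carbon ortho to a large group is read here for the first time: in this assay, isopropyl in place of trifluoromethyl gives a 1.3-fold higher number from compound 2 to compound 3 (0.10 log units; within the scatter). With cyclopentylmethyl on the amide-type nitrogen, this position therefore does not tell trifluoromethyl, with its fluorine atoms, from isopropyl, with carbon only, so for this pair fluorine on the aromatic substituent is not needed to keep the number in this range. No measured property among the data shown accounts for this result.

Compound 1 gives > 10000 nM, which is a limit of the assay and not a number, so the compounds shown do not tell whether the exchange at the aromatic carbon would read the same with isopropyl on the amide-type nitrogen. Also open, on these data alone, are how a methoxy group, a nitrile or a carboxylic acid would read at the aromatic carbon, and how a longer chain or a benzyl group would read on the amide-type nitrogen in this assay.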